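A few compounds are considered here, and "the series" means these few. Any claim that something is new, unique, unknown or untested is made for them only; others in the source may bear on it.

Measured so far in a functional assay on UACC-62 cells (Homo sapiens) for cytotoxicity, read by sulforhodamine B assay; on this read-out lower numbers stand for stronger inhibition of growth and higher numbers for weaker inhibition of growth:

Compound 1 `CC1=CC[C@@H]([C@@](C)(O)CCCC(C)(C)NC(=S)N/N=C\c2ccccc2)CC1` gives 43800 nM.
Compound 2 `CC1=CC[C@@H]([C@@](C)(O)CCCC(C)(C)NC(=S)N/N=C\c2cccc([N+](=O)[O-])c2)CC1` gives 24700 nM.

Compound 2 and compound 1 lie within the scatter of each other; the step of a 1.8-fold lower number from compound 1 to compound 2 (0.25 log units; within the scatter) is the only one in hand, and it shows that putting a nitro group on the aromatic ring moved the number by no more than repeat measurements do.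

Compound 3 `CC1=CC[C@@H]([C@@](C)(O)CCCC(C)(C)NC(=S)N/N=C\c2ccccc2Cl)CC1` has not yet been measured. It differs from compound 2 in one place: 2-chlorophenyl in place of 3-nitrophenyl on a carbon with a double bond to nitrogen. Both groups sit on the same ring attached to the carbon with a double bond to nitrogen. Within the data shown here, the only step that bears on this change is the one from compound 1 to compound 2, and it was within the scatter. No step beyond the scatter is therefore expected in this assay from compound 2 to compound 3. The estimate for compound 3 is 30000 nM, with a range from 12000 nM to 80000 nM. This estimate means an expected step of a 1.2-fold higher number from compound 2 to compound 3 (0.08 log units; within the scatter).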

Compound 3, concentration for total growth inhibition: > 100000 nM
Compound 3 gave a limit, no number; the forecaster's own chance of this, stated with the estimate: 5%; middle value at least 3.3-fold (0.52 log units) from the limit.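

The value of compound 3 in this assay is a limit of the assay, not a number: the limit of > 100000 nM in this assay, at which 1 of the 3 values shown sits.

Even so, the aromatic ring on the carbon with a double bond to nitrogen is not indifferent to what it carries: 2-chlorophenyl in place of 3-nitrophenyl gives an at least 4.0-fold higher number from compound 2 to compound 3 (0.60 log units; beyond the scatter), and chloro in place of hydrogen gives an at least 2.2-fold higher number from compound 1 to compound 3 (0.35 log units; beyond the scatter). Among these compounds, the only earlier step on this ring, nitro in place of hydrogen, stayed within the scatter, so these are the first changes to weaken growth inhibition beyond it.

The compounds shown do not separate the effect of chloro itself from that of its place on the ring, and the full size of both steps remains unknown. As far as these compounds go, how an amine or a carboxylic acid on this ring would read also stays open.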